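The source may report more compounds than this note shows. Statements on the series, on what has been measured and on what is new or still open speak of the compounds shown alone.

Measured compounds:
Compound 1 `COc1ccc(-c2nn3cc(-c4cccc(N)c4)nc3s2)cc1OC` gives 14000 nM in a functional assay on CCRF-CEM cells (Homo sapiens) for inhibition, read by cell counting, with a stated time of 3 days; on this read-out lower numbers stand for stronger inhibition and higher numbers for weaker inhibition.
Compound 2 `COc1cccc(-c2nn3cc(-c4cccc(N)c4)nc3s2)c1` reaches only a limit of this assay, > 250000 nM.
Compound 3 `C=C(Br)C(=O)Nc1cccc(-c2cn3nc(-c4ccc(C)cc4)sc3n2)c1` gives 1700 nM in this assay.

Compound 3 holds the lower of the two real numbers; compound 1, its nearest neighbour, sits well above it, beyond the scatter, and compound 2 contributes only a limit.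

Compound 4 `C=C(Br)C(=O)Nc1cccc(-c2cn3nc(Cc4ccc(Cl)cc4)sc3n2)c1` differs from compound 3 in one place: 4-chlorobenzyl in place of 4-methylphenyl on an aromatic carbon. For the measured compounds named here, the single measured step, an at least 17-fold higher number from compound 1 to compound 2 (1.25 log units; beyond the scatter), concerns the same aromatic carbon of the shared core, and a change there drove the number to the limit (the limit of > 250000 nM in this assay, at which 1 of the 3 values shown sits). Substitution at this position therefore appears sensitive. Swapping 4-methylphenyl for 4-chlorobenzyl is a larger alteration, so a weakening step is expected, a 3.5-fold higher number from compound 3 to compound 4 (0.55 log units; beyond the scatter). Compound 4 is estimated at 6000 nM, most likely between 1500 nM and 25000 nM.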

Compound 4, half-maximal inhibitory concentration: 3300 nM
Compound 4: middle estimate off by 1.8-fold (0.26 log units), on the high side; the measured number falls inside the stated range.
By their numbers in this assay, from the lowest: compounds 3 and 4 (each within the scatter of the next); then compound 1. At a limit, above all of these: compound 2.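

In this assay, the step of a 1.9-fold higher number from compound 3 to compound 4 (0.29 log units; within the scatter) shows that 4-chlorobenzyl and 4-methylphenyl cannot be told apart on this aromatic carbon, even though the change adds a heavy atom and moves the ring further out through the benzyl carbon. For the compounds shown here, the earlier compounds offered no change in one place at this carbon, so this is the first direct reading of it. As far as these compounds go, whether a group other than these two would also be accepted here, such as an amine, a carboxylic acid or a longer alkyl chain, stays open, and so does whether the benzyl link or the chlorine matters on its own. Nothing shown gives a reason for this result.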